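Removing One Methoxy Group: Expected Effect on Cytotoxicity

The compounds below may be only part of what the source reports. "The series", "measured", "known", "first", "only" and "open" are said of these compounds alone.

For the measured compounds named here, compound 2, `COc1ccc(C2CC(c3cc4ccccc4nc3C)=NN2C(C)=O)c(OC)c1OC`, is the only compound here with a plain number: in an ADME assay on A549 cells (Homo sapiens) for cytotoxicity, read by MTT assay, with a stated time of 48 h (on this read-out lower numbers stand for stronger inhibition and higher numbers for weaker inhibition), compound 2 gives 86.5 ug/mL. Compound 1, `COc1cc(C2CC(c3cc4ccccc4nc3C)=NN2C(C)=O)cc(OC)c1OC`, sits at the limit of > 200 ug/mL in this assay, at which 1 of the 2 values shown sits, so in this assay compound 1 gives > 200 ug/mL, which is a limit rather than a number. Compound 3, `COc1ccc(C2CC(c3cc4ccccc4nc3C)=NN2C(C)=O)cc1OC`, differs from compound 2 in one place: hydrogen in place of methoxy on an aromatic carbon. Going by the values given here, no measured step links the two known compounds, so the expected change is modest: a 1.4-fold higher number from compound 2 to compound 3 (0.14 log units; within the scatter), within the usual scatter or slightly toward weaker inhibition. Compound 3 is therefore estimated at 120 ug/mL, with a likely range from 50 ug/mL to 200 ug/mL.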

Compound 3, half-maximal inhibitory concentration: > 200 ug/mL
Compound 3 was reported as a limit; the forecaster's own chance of this, stated with the estimate: 30%; middle value at least 1.6-fold (0.22 log units) from the limit.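

Methoxy on this aromatic carbon, ortho to a large group, matters in this assay: hydrogen in its place gives an at least 2.3-fold higher number from compound 2 to compound 3 (0.36 log units; beyond the scatter), which means weaker inhibition. The result for compound 3 is a limit and not a number, so this step has a lower bound but no full size, and the step from compound 1 to compound 3 cannot be read. Further differences cannot be resolved at this ceiling: the limit of > 200 ug/mL in this assay, at which 2 of the 3 values shown sit.

An amine, a fluorine atom or a longer chain such as ethoxy at this position remains untested among the compounds shown, so it is open whether any of them would match methoxy.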